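This account rests on a few compounds, and the source may have more. Where it says the series, first, only, none or still open, it means among the compounds named here.

Measured so far in a functional assay on MGC-803 cells (Homo sapiens) for cytotoxicity, read by MTT assay, with a stated time of 72 h; on this read-out higher numbers stand for weaker inhibition and lower numbers for stronger inhibition:
compound 1 `FC(F)(F)c1ccc(CSc2nc(Nc3cccc(Cl)c3)c3ccccc3n2)cc1` gives 14600 nM
compound 3 `FC(F)(F)c1ccc(CSc2nc(Nc3ccc(Cl)cc3)c3ccccc3n2)cc1` gives 16800 nM
compound 2 `O=[N+]([O-])c1cccc(Nc2nc(SCc3ccc(C(F)(F)F)cc3)nc3ccccc23)c1` gives only a limit in this assay, > 50000 nM

The change from compound 1 to compound 2 is nitro in place of chloro on an aromatic carbon; it made an at least 3.4-fold higher number from compound 1 to compound 2 (0.53 log units; beyond the scatter), the size being bounded by the limit of > 50000 nM in this assay, at which 1 of the 3 values shown sits. The two cores differ as 4-chlorophenyl in place of 3-chlorophenyl on a nitrogen on an aromatic ring, which gave a 1.2-fold higher number from compound 1 to compound 3 (0.06 log units; within the scatter), while an at least 2.9-fold lower number from compound 2 to compound 3 (0.47 log units; beyond the scatter) is shown between the other pair.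

Compound 4 `O=[N+]([O-])c1ccc(Nc2nc(SCc3ccc(C(F)(F)F)cc3)nc3ccccc23)cc1` is not yet measured; it differs from compound 3 by nitro in place of chloro on an aromatic carbon. This is the same kind of change as from compound 1 to compound 2, though the place differs: there the group sits meta to a large group, here para to a large group. The expected step is a 3.6-fold higher number from compound 3 to compound 4 (0.55 log units; beyond the scatter), resting on an at least 3.4-fold higher number from compound 1 to compound 2 (0.53 log units; beyond the scatter) and on a 1.2-fold higher number from compound 1 to compound 3 (0.06 log units; within the scatter). Compound 4 is thus estimated at 60000 nM, expected between 30000 nM and 150000 nM, quite possibly again reported only as a limit.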

Compound 4, half-maximal inhibitory concentration: 8170 nM
Estimate against measurement, compound 4: 7.3-fold (0.87 log units) above; measured number outside the range, below it.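

On the core of compound 3, nitro in place of chloro gives a 2.1-fold lower number from compound 3 to compound 4 (0.31 log units; beyond the scatter), so in this assay the change does not carry over from the core of compound 1: the same change on two cores in this assay, an at least 3.4-fold higher number (0.53 log units; beyond the scatter) from compound 1 to compound 2 and a 2.1-fold lower number (0.31 log units; beyond the scatter) from compound 3 to compound 4, at least 7.0-fold (0.84 log units) apart, beyond the scatter of two such steps. Among the remaining pairs, 4-nitrophenyl in place of 3-nitrophenyl gives an at least 6.1-fold lower number from compound 2 to compound 4 (0.78 log units; beyond the scatter), while a 1.8-fold lower number from compound 1 to compound 4 (0.25 log units; within the scatter) is a step within the scatter. This shows no rule beyond these four compounds, and compound 2 stands only as a limit: the limit of > 50000 nM in this assay, at which 1 of the 4 values shown sits.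

From the compounds shown here alone, how an amine, a methoxy group or a carboxylic acid in place of chloro would behave at either place stays open. Also open, going by these compounds, is how replacing trifluoromethyl with a nitrile would bear on these steps.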